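The source may hold more compounds than are shown below. What is called first, only, known or untested is meant among the compounds shown, and "the series" means these compounds.

Compound 1, whose structure is `Cc1ccc(NS(=O)(=O)c2ccc(-c3ccccc3)cc2)cc1O`, is a sulfonamide carrying a phenyl group on its outer ring. In a functional assay on A549 cells (Homo sapiens) for inhibition (on this read-out higher numbers stand for weaker inhibition of growth and lower numbers for stronger inhibition of growth), compound 1 gives 9000 nM. Compound 2, with the structure `Cc1ccc(NS(=O)(=O)c2ccc(Oc3ccccc3)cc2)cc1O`, differs from compound 1 only by the change (phenoxy in place of phenyl on an aromatic carbon), and in this assay compound 2 gives 7000 nM. That change made a step of a 1.3-fold lower number from compound 1 to compound 2 (0.11 log units; within the scatter), so the two values sit together.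

Compound 3, with the structure `Cc1cc(C2(c3ccccc3)C(=O)Nc3ccccc32)c(NS(=O)(=O)c2ccc(-c3ccccc3)cc2)cc1O`, keeps the phenyl-bearing sulfonamide of compound 1 but is built on a larger core; the difference between the two cores is not broken down here. In this assay compound 3 gives 4000 nM.

Compound 4, whose structure is `Cc1cc(C2(c3ccccc3)C(=O)Nc3ccccc32)c(NS(=O)(=O)c2ccc(Oc3ccccc3)cc2)cc1O`, is not yet measured. It stands to compound 3 as compound 2 stands to compound 1, through the same change (phenoxy in place of phenyl on an aromatic carbon), made at the same kind of position on the outer ring. Since the earlier step was a 1.3-fold lower number from compound 1 to compound 2 (0.11 log units; within the scatter), the step from compound 3 to compound 4 is expected to be a 1.3-fold lower number from compound 3 to compound 4 (0.12 log units; within the scatter). Compound 4 is therefore estimated at 3000 nM, expected to lie between 1500 nM and 6500 nM in this assay.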

Compound 4, concentration for 50% growth inhibition: 5000 nM
Beside the measured number, compound 4's estimate is 1.7-fold (0.22 log units) below it; the range from low to high includes it.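

In this assay, phenoxy in place of phenyl on the larger core gives a 1.3-fold higher number from compound 3 to compound 4 (0.10 log units; within the scatter), so on this core the two groups cannot be told apart. The same change on the two cores gives steps that agree as far as these data can tell: the same change on two cores in this assay, a 1.3-fold lower number (0.11 log units; within the scatter) from compound 1 to compound 2 and a 1.3-fold higher number (0.10 log units; within the scatter) from compound 3 to compound 4, 1.6-fold (0.21 log units) apart, within the scatter of two such steps. This shows that the swap stays within the scatter on both cores, but it does not show that a real effect of a change carries from one core to the other, as neither step is large enough to test that, and the different directions of the two small steps should not be read as a real difference.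

The compounds shown leave open whether a different group at this place, such as an amine, a carboxylic acid or a longer chain, would give a step beyond the scatter. If one did, it would also remain to be seen whether that step held on both cores.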